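Phenyl for Amino on a Triazole Bearing a Chromone

The source may report more compounds than this note shows. Statements on the series, on what has been measured and on what is new or still open speak of the compounds shown alone.

Measured compounds:
compound 1 `Cc1cc(C)n2nc(SCc3nnc(SCc4coc5ccccc5c4=O)n3-c3ccccc3)nc2n1`: 16600 nM
compound 2 `Cc1cc(C)n2nc(SCc3nnc(SCc4cc(=O)c5ccccc5o4)n3N)nc2n1`: > 25000 nM

In a functional assay on LM7 cells (Homo sapiens) for cytotoxicity, read by MTT assay, with a stated time of 72 h (on this read-out higher numbers stand for weaker inhibition and lower numbers for stronger inhibition), compound 1 gives 16600 nM. For compound 2 the assay reports only a limit, > 25000 nM. Compound 2 thus stands at the weak end of what is seen here, as the limit of > 25000 nM in this assay, at which 1 of the 2 values shown sits, shows. Compound 3 `Cc1cc(C)n2nc(SCc3nnc(SCc4cc(=O)c5ccccc5o4)n3-c3ccccc3)nc2n1` differs from compound 2 in one place: phenyl in place of amino on an aromatic nitrogen. Among the compounds with values here, no measured step links the two, and both known values sit at weak inhibition, so no shift beyond the usual scatter is expected. Compound 3 is therefore expected to give 22000 nM in this assay, within 8000 nM to 60000 nM. The step of an at least 1.1-fold lower number from compound 2 to compound 3 (0.05 log units; that floor lies within the scatter) is expected to stay small.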

Compound 3, half-maximal inhibitory concentration: > 25000 nM
Compound 3 was reported as a limit; the forecaster's own chance of this, stated with the estimate: 45%; at least 1.1-fold (0.05 log units) between middle value and limit.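

Compound 2 and compound 3 are both reported only as limits, so the swap of amino for phenyl on the aromatic nitrogen cannot be read: the limit of > 25000 nM in this assay, at which 2 of the 3 values shown sit. Phenyl on this nitrogen does not on its own give a value that can be read, as compound 3 shows. Changing only the group of 11 heavy atoms on a saturated chain carbon bound to a sulfur gives an at least 1.5-fold higher number from compound 1 to compound 3 (0.17 log units; that floor lies within the scatter), so these two cannot be ranked. On these data alone, whether a methyl group or a longer chain on that nitrogen would give a readable value remains open.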